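Swapping the Hydroxyphenyl Arm for a Pyridine

This account rests on a few compounds, and the source may have more. Where it says the series, first, only, none or still open, it means among the compounds named here.

Compound 1 `COc1ccc(S(=O)(=O)N2CCc3cccc(-c4ccc(O)cc4)c32)cc1` holds the lowest number among the three measured compounds: in a functional assay on KB-VIN10 cells (Homo sapiens) for inhibition, with a stated time of 72 h (a lower number here means a stronger inhibitor, a higher number a weaker inhibitor), compound 1 gives 123 nM. In this assay compound 2 `COc1ccc(S(=O)(=O)N2CCc3cccc(-c4c(F)c(F)c(F)c(F)c4F)c32)cc1` gives 4630 nM, and compound 3 `COc1ccc(S(=O)(=O)N2CCc3cccc(-c4cc(OC)c(OC)c(OC)c4)c32)cc1` gives 4670 nM, both far beyond the scatter from compound 1. Compound 4 `COc1ccc(S(=O)(=O)N2CCc3cccc(-c4ccncc4)c32)cc1` has not yet been measured. It differs from compound 1 in one place: pyridin-4-yl in place of 4-hydroxyphenyl on an aromatic carbon. Within the data shown here, no measured pair shares this exact change, so the expectation rests on the wider picture. A weakening step is expected, a 4.9-fold higher number from compound 1 to compound 4 (0.69 log units; beyond the scatter), because compound 1 stands alone at 123 nM while every other replacement at the same position gave a much higher number. Compound 4 is therefore estimated at 600 nM, with a range from 120 nM to 3000 nM.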

Compound 4, half-maximal inhibitory concentration: 106 nM
For compound 4 the middle estimate is 5.7-fold (0.75 log units) above the measured one; the measured number lies below the stated range.
By their numbers in this assay, from the lowest: compounds 4 and 1 (each within the scatter of the next); then compounds 2 and 3 (each within the scatter of the next).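

The swap of pyridin-4-yl for 4-hydroxyphenyl in this assay gives a 1.2-fold lower number from compound 1 to compound 4 (0.06 log units; within the scatter). A low number at this position therefore does not depend on the hydroxyl group or on a hydrogen-bond donor in the arm, since pyridin-4-yl has none, and a ring nitrogen serves as well. No measurement here explains this result.

Still open, going by these compounds, is how 4-aminophenyl, which carries an amine, would compare with compound 1. Also open, on these data alone, is whether pyridin-3-yl would match compound 4.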